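The compounds below may be only part of what the source reports. "The series", "measured", "known", "first", "only" and "open" are said of these compounds alone.

In a functional assay on HBL-100 cells (Homo sapiens) for inhibition, read by sulforhodamine B assay, with a stated time of 48 h (a higher number here means a weaker inhibitor of growth, a lower number a stronger inhibitor of growth), compound 1 `COC(=O)[C@@]1(C)CC[C@@H]2C3=C1CC[C@@H](C)[C@]3(C)Cc1c2[nH]c2ccccc12` gives 3500 nM, and compound 2 `COC(=O)[C@@]1(C)CC[C@@H]2C3=C1CC[C@@H](C)[C@]3(C)Cc1c2[nH]c2ccc(OC)cc12` gives 5000 nM, so the two sit within the scatter of each other; the step of a 1.4-fold higher number from compound 1 to compound 2 (0.15 log units; within the scatter) is the only one measured. Compound 3 `COC(=O)[C@@]1(C)CC[C@@H]2C3=C1CC[C@@H](C)[C@]3(C)Cc1c2[nH]c2c(C)cccc12` differs from compound 1 by methyl in place of hydrogen on an aromatic carbon. The measured step adds a different small group, so it bears on this change only loosely; it shows that a single small aromatic substituent moved the number little. Compound 3 is therefore expected to give 3500 nM, within a range of 1500 nM to 8000 nM. That estimate means no change at the digits printed from compound 1 to compound 3 (within the scatter), nothing beyond the scatter.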

Compound 3, concentration for 50% growth inhibition: 13000 nM
Compound 3: middle estimate off by 3.7-fold (0.57 log units), on the low side; measured number above the stated range.
By their numbers in this assay, from the lowest: compounds 1 and 2 (each within the scatter of the next); then compound 3.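

In this assay, methyl in place of hydrogen on this aromatic carbon gives a 3.7-fold higher number from compound 1 to compound 3 (0.57 log units; beyond the scatter), so a single added carbon at this place weakens growth inhibition by more than the scatter. The methoxy change, a 1.4-fold higher number from compound 1 to compound 2 (0.15 log units; within the scatter), showed no such loss, so a small substituent on this aromatic ring does not always leave the number unchanged. No measurement shown explains the rise. From the compounds shown here alone, whether an ethyl group or an amine on this same carbon would give a larger or smaller step remains open. So does the effect of methyl on the other carbons of this ring.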